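The compounds below may be only part of what the source reports. "The series", "measured", "known", "first", "only" and "open" are said of these compounds alone.

Measured in a physicochemical assay for lipophilicity, read by HPLC; on this read-out higher numbers stand for higher lipophilicity and lower numbers for lower lipophilicity:
- compound 1 `COc1cccc(NC(=O)c2ccc3cccc(O)c3n2)c1`: 2.5
- compound 2 `O=C(Nc1cccc(F)c1)c1ccc2cccc(O)c2n1`: 2.5
- compound 3 `O=C(Nc1cccc(C(F)(F)F)c1)c1ccc2cccc(O)c2n1`: 2.5

Compound 3 stands level with compounds 1 and 2 in this assay at the digits given; the three values lie within the scatter of one another, so no order among them can be read. The next compound, compound 4 `O=C(Nc1cccc([N+](=O)[O-])c1)c1ccc2cccc(O)c2n1`, differs from compound 3 in one place: nitro in place of trifluoromethyl on an aromatic carbon. Within the data shown here, three measured steps bear on this change, since each of them also swaps the group on the same aromatic carbon while the rest of the molecule is held fixed: no change at the digits printed from compound 1 to compound 2 (within the scatter), no change at the digits printed from compound 1 to compound 3 (within the scatter) and no change at the digits printed from compound 2 to compound 3 (within the scatter). Each of these swaps left this assay unchanged within the scatter, although none of them introduced a nitro group. On that basis compound 3 to compound 4 is expected to show a number 0.10 log units lower from compound 3 to compound 4 (within the scatter), that is, no step beyond the scatter, with room for a small drop. The estimate for compound 4 in this assay is therefore 2.4, expected to lie between 1.9 and 2.9.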

Compound 4, partition coefficient: 2.5
For compound 4 the middle estimate is 0.10 log units below the measured one, and the stated range covers the measured number.
By their numbers in this assay, from the lowest: compounds 1, 2, 3 and 4 (each within the scatter of the next).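

With nitro in place of trifluoromethyl on an aromatic carbon meta to a large group, this assay shows no change at the digits printed from compound 3 to compound 4 (within the scatter) and so extends the flat result to a group built of nitrogen and oxygen, with a double bond outside aromatic rings. The comparisons with the other two compounds read the same way: nitro in place of fluoro gives no change at the digits printed from compound 2 to compound 4 (within the scatter) and nitro in place of methoxy gives no change at the digits printed from compound 1 to compound 4 (within the scatter) so that all four groups at this position now stand level within the scatter. Nothing among the data shown offers an explanation for this flat result.

Going by these compounds, whether an amine, a carboxylic acid or a longer chain at this position would stay level with these four remains open. So does whether the same swaps would read alike at another carbon of this aromatic ring.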